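The source may hold more compounds than are shown below. What is called first, only, known or untested is meant among the compounds shown, and "the series" means these compounds.

Of the compounds shown here, two have been tested in a functional assay on Urethra for agonist activity at Alpha-1A adrenergic receptor (Oryctolagus cuniculus); on this read-out higher numbers stand for higher potency (the scale is a negative logarithm) and lower numbers for lower potency. Compound 1, `CC(=O)Nc1cccc2c1CCCC2c1c[nH]cn1`, gives 5.89 in this assay. Compound 2, `CCS(=O)(=O)Nc1cccc(Cc2c[nH]cn2)c1`, gives 6.22 in this assay and so stands highest of the two numbers; the nearest value, that of compound 1, lies lower by a margin beyond the usual scatter. Compound 3, `CCS(=O)(=O)Nc1cccc(Cc2c[nH]cn2)c1C`, has not yet been measured. It differs from compound 2 in one place: methyl in place of hydrogen on an aromatic carbon. Among the compounds with values here, no step between measured compounds shows what such a change does on this read-out, so no size can be drawn from the data. On the two values available, the expectation for compound 3 is a small step in this assay, if anything slightly upward and probably not beyond the scatter, and the estimated change is a number 0.08 log units higher from compound 2 to compound 3 (within the scatter). Compound 3 is thus expected to give about 6.3 in this assay, within a range from 5.7 to 6.9.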

Compound 3, negative logarithm of the half-maximal effective concentration: 5.6
Compound 3: the middle estimate sits 0.70 log units above what was measured; the measured number lies below the stated range.
By their numbers in this assay, from the lowest: compounds 3 and 1 (each within the scatter of the next); then compound 2.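

This position does not tolerate every change: in this assay, methyl in place of hydrogen on the aromatic carbon ortho to the (1H-imidazol-4-yl)methyl group and ortho to the (ethylsulfonyl)amino group gives a number 0.62 log units lower from compound 2 to compound 3 (beyond the scatter) and is the only step of its kind shown for this series. One added carbon is thus enough to move the read-out downward beyond the scatter. Nothing available explains this drop.

On these data alone, whether the loss belongs to methyl itself or to any group at this carbon stays open, and a fluorine atom, a hydroxyl group or a methoxy group there would help to separate the two. Also open, as far as these compounds go, is whether methyl on another aromatic carbon of compound 2 would lower the number to a similar extent.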